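The source may hold more compounds than are shown below. What is called first, only, known or untested is meant among the compounds shown, and "the series" means these compounds.

Compound 1, `COc1ccc(-c2cccc(C(=O)N(C)C)c2)cc1S(=O)(=O)Nc1ccc2ccc(NC(=O)c3ccccc3)cc2c1`: in a functional assay on CHO cells for agonist activity at Orexin receptor type 2 (Homo sapiens) (a higher number here means that more compound is needed for the effect, a lower number that less compound is needed), compound 1 gives > 10000 nM, which is a limit of the assay and not a number.
Compound 2, `COc1ccc(-c2cccc(C(=O)N(C)C)c2)cc1S(=O)(=O)Nc1ccc2ccc(N(C)C(=O)c3ccccc3)cc2c1`: in this assay compound 2 gives > 10000 nM, again a limit of the assay rather than a number.
Compound 3, `COc1cccc(C(=O)Nc2c(C)ccc3ccc(NS(=O)(=O)c4cc(-c5cccc(C(=O)N(C)C)c5)ccc4OC)cc23)c1`: in this assay compound 3 gives 9.21 nM.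

Compound 4, `COc1cccc(C(=O)N(C)c2c(C)ccc3ccc(NS(=O)(=O)c4cc(-c5cccc(C(=O)N(C)C)c5)ccc4OC)cc23)c1`, has not yet been measured. It differs from compound 3 in one place only, (methyl in place of hydrogen on an amide-type nitrogen). The same change has already been made once among the measured compounds, from compound 1 to compound 2, (methyl in place of hydrogen on an amide-type nitrogen), and the surroundings of the changed nitrogen are described in identical words in both cases. Yet the measured pair teaches little about its size: the step that the two limits leave unreadable from compound 1 to compound 2 cannot be read because of the limit of > 10000 nM in this assay, at which 2 of the 3 values shown sit, so the change may have helped, hurt or done nothing there. How the core of compound 1 differs from the core of compound 3 is not broken down here.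

Compound 3 is the only one of the three with a number rather than a limit, and it sits well inside the measurable range, so the same change on it should give a readable step. For the measured compounds named here, with no usable precedent, the expected step of a 6.5-fold higher number from compound 3 to compound 4 (0.81 log units; beyond the scatter) is set as a modest loss with wide uncertainty. Compound 4 is thus estimated at 60 nM, expected to fall between 6 nM and 1500 nM.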

Compound 4, half-maximal effective concentration: 31.1 nM
For compound 4 the middle estimate is 1.9-fold (0.29 log units) above the measured one; measured number inside the range.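

In this assay, placing a methyl on the amide-type nitrogen gives a 3.4-fold higher number from compound 3 to compound 4 (0.53 log units; beyond the scatter), so on the core of compound 3 the amide hydrogen can be replaced at a modest cost, and compound 4 still gives a number well inside the measurable range. The same change on the core of compound 1 offers nothing to set beside this step, since the step from compound 1 to compound 2 cannot be read: the limit of > 10000 nM in this assay, at which 2 of the 4 values shown sit. This leaves a single readable pair, which gives the size of the change on one core only and does not show that the change would cost the same on another core, so whether the step carries from one core to another remains an open question.

The compounds shown carry only hydrogen or methyl on this nitrogen, leaving open what an ethyl group, a longer chain or a chain ending in an amine would do there in this assay. They also leave open how large the methyl step would be on any other core where both partners of the pair give a number rather than a limit.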